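One Ring Swapped on a Side Chain

The compounds below may be only part of what the source reports. "The series", "measured", "known", "first", "only" and "open" are said of these compounds alone.

In a toxicity assay on HEK-293T cells (Homo sapiens) for cytotoxicity, read by MTT assay, with a stated time of 72 h (a lower number here means a stronger inhibitor, a higher number a weaker inhibitor), three compounds with a shared core have been measured. Compound 1 (`CC1(C)OCC(Cn2cc(Cn3c4c(c5ccccc53)C(=O)c3c[n+]([O-])c5ccccc5c3C4=O)nn2)O1`) gives 5510 nM and compound 2 (`CC1(C)O[C@@H](CO)[C@H](Cn2cc(Cn3c4c(c5ccccc53)C(=O)c3c[n+]([O-])c5ccccc5c3C4=O)nn2)O1`) gives 120 nM while compound 3 (`CN1CCN(CCCn2c3c(c4ccccc42)C(=O)c2c[n+]([O-])c4ccccc4c2C3=O)CC1`) gives 170 nM on the same read-out. Compound 3 therefore lies within the scatter of compound 2 and far under compound 1.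

Compound 4 (`O=C1c2c[n+]([O-])c3ccccc3c2C(=O)c2c1c1ccccc1n2CCCN1CCC(O)CC1`) carries 4-hydroxypiperidin-1-yl in place of 4-methylpiperazin-1-yl (4-hydroxypiperidin-1-yl in place of 4-methylpiperazin-1-yl on a saturated chain carbon, three bonds along the chain from an aromatic nitrogen) on a saturated chain carbon, three bonds along the chain from an aromatic nitrogen. Going by the values given here, the only measured step (a 46-fold lower number from compound 1 to compound 2 (1.66 log units; beyond the scatter)) is large, but it adds a hydroxymethyl on a different side chain, so it says little about this ring swap. Among the compounds with values here, no measured pair changes this ring itself. No step beyond the scatter is therefore expected, and the estimate (a 1.5-fold higher number from compound 3 to compound 4 (0.17 log units; within the scatter)) points slightly upward. Compound 4 is expected at about 250 nM (estimated range 70 nM to 1000 nM).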

Compound 4, half-maximal inhibitory concentration: 170 nM
Beside the measured number, compound 4's estimate is 1.5-fold (0.17 log units) above it, and the stated range covers the measured number.
By their numbers in this assay, from the lowest: compounds 2, 3 and 4 (each within the scatter of the next); then compound 1.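

Going by these compounds alone, the ring swap gives no change at the digits printed from compound 3 to compound 4 (within the scatter) in this assay, and it is the only measured change of this ring itself. On this propyl chain, then, 4-hydroxypiperidin-1-yl, with its hydroxyl group and a single ring nitrogen, reads the same as 4-methylpiperazin-1-yl, with its two ring nitrogens and N-methyl group, so this one exchange of ring atoms and substituent leaves the toxicity read-out unmoved. Nothing among the data given explains why the two rings read alike.

As far as these compounds go, this is a single pair, so it remains open whether other groups at the end of the chain, such as morpholine or an open-chain dimethylamino group, would read the same. From the compounds shown here alone, a butyl chain in place of the propyl chain, carrying either ring, is equally open.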